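The source may report more compounds than this note shows. Statements on the series, on what has been measured and on what is new or still open speak of the compounds shown alone.

Measured so far in a physicochemical assay for solubility, read by nephelometry, measured as kinetic solubility; on this read-out higher numbers stand for higher solubility and lower numbers for lower solubility:
compound 1 `COc1cc(OC)cc(C(=O)Nc2ccc(Nc3nc(C)cc(N(C)C)n3)cc2)c1` gives 20000 nM.
compound 2 `Cc1cc(N(C)C)nc(NCc2ccccc2)n1` gives > 250000 nM, which is a limit of the assay and not a number.
compound 3 `Cc1cc(N(C)C)nc(N[C@H]2CC[C@H](NC(=O)c3ccccc3)CC2)n1` gives > 250000 nM, again a limit of the assay and not a number.

Compound 3 therefore stands at the top of what this assay can report. Two of the three values recorded for the series sit at the same point, (the limit of > 250000 nM in this assay, at which 2 of the 3 values shown sit), so only compound 1 has given a number inside the measurable window.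

The next compound, compound 4 `COc1cc(OC)cc(C(=O)N[C@H]2CC[C@H](Nc3nc(C)cc(N(C)C)n3)CC2)c1`, keeps the whole of compound 3 apart from one change: 3,5-dimethoxyphenyl in place of phenyl on a carbonyl carbon. Among the compounds with values here, no measured pair shows this exact change, so the size of the step in this assay can only be expected, not read off. Compound 1 carries the same 3,5-dimethoxyphenyl group on a different scaffold and gives a number below the limit, so a value inside the window for compound 4 cannot be ruled out, but a step of more than the scatter downward is not expected. The step from compound 3 to compound 4 is expected to be an at least 1.6-fold lower number from compound 3 to compound 4 (0.22 log units; that floor lies within the scatter). Compound 4 is thus estimated at 150000 nM, with a range from 40000 nM to 250000 nM.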

Compound 4, solubility: > 250000 nM
Compound 4: no number, only a limit (the forecaster's own chance of this, stated with the estimate: 45%); middle value at least 1.6-fold (0.22 log units) from the limit.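

Compound 3 and compound 4 both stand at a limit of this assay and not at a number, so no step can be read for 3,5-dimethoxyphenyl in place of phenyl on a carbonyl carbon: the limit of > 250000 nM in this assay, at which 3 of the 4 values shown sit.

The compounds shown leave open whether compound 4 differs from compound 3 at all in this assay, and in which direction.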